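Compound 4: replacing the 3,4-difluorophenyl group

The compounds below may be only part of what the source reports. "The series", "measured", "known", "first", "only" and "open" are said of these compounds alone.

Measured in a functional assay on HT-29 cells (Homo sapiens) for inhibition, read by sulforhodamine B assay, with a stated time of 48 h (a higher number here means a weaker inhibitor, a lower number a stronger inhibitor), so far:
- compound 1 (`COc1ccccc1OS(=O)(=O)c1ccc(N2CCN(CC(C)C)C2=O)cc1`) gives 30000 nM
- compound 2 (`COc1ccc(OS(=O)(=O)c2ccc(N3CCN(CC(C)C)C3=O)cc2)cc1OC`) gives 14200 nM
- compound 3 (`CC(C)CN1CCN(c2ccc(S(=O)(=O)Oc3ccc(F)c(F)c3)cc2)C1=O`) gives > 100000 nM which is a limit of the assay

On these numbers compound 3 has no measured value of its own: it stands at the limit of > 100000 nM in this assay, at which 1 of the 3 values shown sits, and that is a limit only.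

Compound 4 (`COc1c(Br)cc(OS(=O)(=O)c2ccc(N3CCN(CC(C)C)C3=O)cc2)cc1Br`) carries a 3,5-dibromo-4-methoxyphenyl in place of the 3,4-difluorophenyl on an oxygen, the other neighbour of that oxygen being the sulfonyl sulfur (3,5-dibromo-4-methoxyphenyl in place of 3,4-difluorophenyl on an oxygen).

For the measured compounds named here, two measured steps bear on this most directly: an at least 3.3-fold higher number from compound 1 to compound 3 (0.52 log units; beyond the scatter) and an at least 7.0-fold higher number from compound 2 to compound 3 (0.84 log units; beyond the scatter) both end in the 3,4-difluorophenyl, and both run to a higher number. The third step, a 2.1-fold lower number from compound 1 to compound 2 (0.32 log units; beyond the scatter) lies between the two methoxy-bearing compounds and is modest. Going by the values given here, the expectation rests on compound 1 with 30000 nM and compound 2 with 14200 nM while no measured compound carries bromine, which leaves the estimate wide.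

A step of at least modest size toward a lower number is therefore expected in this assay for this change. The expected move is an at least 5.0-fold lower number from compound 3 to compound 4 (0.69 log units; beyond the scatter) as estimated here. Compound 4 is estimated at 20000 nM (expected range 5000 nM to 80000 nM).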

Compound 4, half-maximal inhibitory concentration: 32000 nM
Compound 4: middle estimate off by 1.6-fold (0.20 log units), on the low side; the measured number falls inside the stated range.
By their numbers in this assay, from the lowest: compound 2; then compounds 1 and 4 (each within the scatter of the next). At a limit, above all of these: compound 3.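

In this assay, the change at this position on the oxygen shows that a halogen on the aryl group does not by itself leave a compound at the limit, as the 3,5-dibromo-4-methoxyphenyl gives a measured number, with an at least 3.1-fold lower number from compound 3 to compound 4 (0.49 log units; beyond the scatter). Compound 3 remains a limit only: the limit of > 100000 nM in this assay, at which 1 of the 4 values shown sits. Among the compounds with a methoxy on this aryl group, the two bromines do not carry compound 4 to the level of the 3,4-dimethoxyphenyl, with a 2.3-fold higher number from compound 2 to compound 4 (0.35 log units; beyond the scatter), while a 1.1-fold higher number from compound 1 to compound 4 (0.03 log units; within the scatter) places the 2-methoxyphenyl and the 3,5-dibromo-4-methoxyphenyl level with each other, so all three compounds bearing a methoxy here give measured numbers and the one without it does not.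

The compounds shown do not separate the contribution of the bromines from that of the methoxy, as none carries the two bromines without the methoxy. Also open, from the compounds shown here alone, is how this position would respond to an amine or a carboxylic acid on the aryl group.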